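The source may hold more compounds than are shown below. What is called first, only, known or untested is meant among the compounds shown, and "the series" means these compounds.

Measured compounds:
Compound 1 `COc1ccc2c(S(=O)(=O)c3ccccc3)cn(CCN)c2c1`; in an assay on HeLa cells for inhibition of 5-hydroxytryptamine receptor 6 (Homo sapiens), tested at 1 uM (a lower number here means less inhibition, a higher number more inhibition at the concentration tested (going by the name of the read-out)), compound 1 gives 78%.
Compound 2 `COc1ccc2c(c1)c(S(=O)(=O)c1ccccc1)cn2CCN`; in this assay compound 2 gives 86%.
Compound 3 `CN(C)CCn1cc(S(=O)(=O)c2ccccc2)c2ccc(C#N)cc21`; in this assay compound 3 gives 42%.

Compound 2 shows the largest of the three numbers, but compound 1 sits within the usual scatter of it, so the two cannot be ranked against each other. Compound 3 lies clearly lower, beyond the scatter, though it differs from compound 2 in more than one place, so no single cause can be read from that gap.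

The unmeasured compound 4 `COc1ccc2c(c1)c(S(=O)(=O)c1ccccc1)cn2CCN1CCCCC1` differs from compound 2 in one place: piperidin-1-yl in place of amino on a saturated chain carbon, two bonds along the chain from an aromatic nitrogen. Among the compounds with values here, no pair of measured compounds shows this change on its own, so there is no measured step to lean on. The expectation for compound 4 is a moderate drop, with the step of a number 16 percentage points lower from compound 2 to compound 4 (beyond the scatter) likely reaching beyond the scatter but not certainly so. Compound 4 is therefore estimated at 70%, with a range from 40% to 92%.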

Compound 4, a percentage reported as inhibition, at one concentration (the size of the read-out at that concentration, not a potency): 55%
For compound 4 the middle estimate is 15 percentage points above the measured one; the measured number falls inside the stated range.
By their numbers in this assay, from the lowest: compound 3; then compound 4; then compounds 1 and 2 (each within the scatter of the next).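

Within the data shown here, replacing amino with piperidin-1-yl gives the only measured step at this position: in this assay, there is a number 31 percentage points lower from compound 2 to compound 4 (beyond the scatter), which counts as a large step. What sits on the saturated chain carbon, two bonds along the chain from an aromatic nitrogen, therefore clearly affects the read-out, although the inhibition is not lost altogether, as compound 4 still gives 55% at the concentration tested. No measurement shown here explains why the number falls.

On these data alone, it remains open where a smaller ring such as pyrrolidin-1-yl, a ring with a second hetero atom such as morpholin-4-yl, or a longer chain ending in amino would fall relative to compound 2 and compound 4. The compounds also leave open whether the same swap would give a step of similar size on the core of compound 1.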